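The source may hold more compounds than are shown below. What is called first, only, known or untested is meant among the compounds shown, and "the series" means these compounds.

Compound 1 `CNC(=O)OC[C@H]1OC(n2cnc3c(NC4CCOC4)nc(Cl)nc32)[C@H](O)[C@@H]1O` gives 96 nM in an assay on DDT1 cells (Cricetulus griseus) for binding affinity to adenosine receptor A1 (Homo sapiens), read by radioligand binding; on this read-out higher numbers stand for weaker inhibition and lower numbers for stronger inhibition.
Compound 2 `C/N=C(\S)OC[C@H]1OC(n2cnc3c(NC4CCOC4)ncnc32)[C@H](O)[C@@H]1O` gives 45 nM in this assay.
Compound 3 `CCCNC(=O)OC[C@H]1OC(n2cnc3c(NC4CCOC4)ncnc32)[C@H](O)[C@@H]1O` gives 235 nM in this assay.

Compound 3 stands highest of the three numbers in this assay; compound 1 lies nearest to it and compound 2 furthest, both differences being beyond the scatter. Compound 4 `CCCC/N=C(\S)OC[C@H]1OC(n2cnc3c(NC4CCOC4)ncnc32)[C@H](O)[C@@H]1O` differs from compound 3 in one place: a group of 7 heavy atoms (5 carbon, 1 nitrogen, 1 sulfur; no ring) in place of a group of 6 heavy atoms (4 carbon, 1 nitrogen, 1 oxygen; no ring), on an oxygen on a saturated carbon. Among the measured compounds shown here, one measured step bears on this change, namely a 5.2-fold higher number from compound 2 to compound 3 (0.72 log units; beyond the scatter), in which a shorter sulfur-bearing group gave way to the propylcarbamoyl group. Compound 4 returns to a sulfur-bearing group while keeping the longer chain of compound 3, so it undoes only part of what that step changed. A lower number is therefore expected for compound 4, though not the full size of the measured step, since the chain length also changed there. The step from compound 3 to compound 4 is estimated at a 2.4-fold lower number from compound 3 to compound 4 (0.37 log units; beyond the scatter). Compound 4 is accordingly expected to give about 100 nM in this assay, within a range of 40 nM to 250 nM.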

Compound 4, inhibition constant: 157 nM
For compound 4 the middle estimate is 1.6-fold (0.20 log units) below the measured one; measured number inside the range.
By their numbers in this assay, from the lowest: compound 2; then compounds 1, 4 and 3 (each within the scatter of the next, the first and the last beyond it).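

In this assay, a 1.5-fold lower number from compound 3 to compound 4 (0.18 log units; within the scatter), so at this place, on an oxygen on a saturated carbon, the propylcarbamoyl group and the sulfur-bearing group of compound 4 cannot be told apart. Among the compounds shown here, the chain on the sulfur-bearing group does register: propyl in place of hydrogen on a saturated chain carbon bound to a double-bonded nitrogen gives a 3.5-fold higher number from compound 2 to compound 4 (0.54 log units; beyond the scatter) in the same assay, a change in chain length that the earlier compounds could not separate from the exchange of groups. Nothing available explains either step.

The compounds shown leave open whether a chain longer than that of compound 4, or a phenyl or an amine at its end, would carry this trend further. They also leave open whether the same step holds with the chlorine that compound 1 carries on the core.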